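Swapping Fluoro for Methyl on the Aryl Ring of Compound 3

The compounds below may be only part of what the source reports. "The series", "measured", "known", "first", "only" and "open" are said of these compounds alone.

Of the compounds shown here, three sharing one core have been measured in an ADME assay on the whole organism with Oryza sativa as the target, tested at 10 uM; a lower number here means a stronger effect, a higher number a weaker effect of the compound at the concentration tested. Compound 1 `Cc1ccc(NC(=O)N[C@H](C)c2ccccc2)cc1` gives 64%. Compound 2 `C[C@@H](NC(=O)Nc1ccc(F)cc1)c1ccccc1` gives 92%, and compound 3 `C[C@@H](NC(=O)Nc1ccc(F)cc1F)c1ccccc1` gives 93%. Compound 2 and compound 1 differ in one place: methyl in place of fluoro on an aromatic carbon. That single change brought a number 28 percentage points lower from compound 2 to compound 1 (beyond the scatter). Compound 2 and compound 3 differ by fluoro in place of hydrogen on an aromatic carbon; the step of a number 1 percentage points higher from compound 2 to compound 3 (within the scatter) leaves the two values within the scatter of each other, so nothing separates them. The values of compound 3 and compound 1, however, lie beyond the scatter apart.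

Compound 4 `Cc1cc(F)ccc1NC(=O)N[C@H](C)c1ccccc1` is still to be measured. It differs from compound 3 by methyl in place of fluoro on an aromatic carbon. Within the data shown here, this is the same kind of change as the one seen from compound 2 to compound 1, but the surroundings are not identical: in that pair the new methyl sits para to a large group, whereas in compound 4 it sits ortho to a large group and meta to a fluoro group. Among the measured compounds shown here, only a single measured example of this change exists, so any expectation rests on that one pair alone. The expected step from compound 3 to compound 4 is a number 18 percentage points lower from compound 3 to compound 4 (beyond the scatter), taken somewhat smaller than the earlier one because a number 28 percentage points lower from compound 2 to compound 1 (beyond the scatter) was seen at a different place on the ring. Compound 4 is therefore expected to give about 75%. The estimate for compound 4 is expected to fall between 55% and 92%.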

Compound 4, a percentage reported as activity, at one concentration (the size of the read-out at that concentration, not a potency): 94%
Estimate against measurement, compound 4: 19 percentage points below, outside the stated range (above it).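

In this assay, methyl in place of fluoro on an aromatic carbon gave a number 1 percentage points higher from compound 3 to compound 4 (within the scatter), and the other single change that leads to compound 4 gave a number 2 percentage points higher from compound 2 to compound 4 (within the scatter), so neither step separates compound 4 from its neighbour. The same swap of fluoro for methyl therefore did not carry over from one core to the other in this series, and the two outcomes truly differ: the same change on two cores in this assay, a number 28 percentage points lower (beyond the scatter) from compound 2 to compound 1 and a number 1 percentage points higher (within the scatter) from compound 3 to compound 4, 29 percentage points apart, beyond the scatter of two such steps This warns against adding the earlier step onto another core here, but it does not show why the two steps differ: the methyl of compound 4 sits ortho to a large group and meta to a fluoro group, unlike the methyl of compound 1, and two pairs cannot give a cause or a general rule.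

The compounds shown carry only fluoro and methyl on the ring that changes, so it remains open how a chloro, a methoxy or a nitrile there would read in this assay. Also open, as far as these compounds go, is what a methyl ortho to a large group would give on a ring with no fluoro at all.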